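The source may report more compounds than this note shows. Statements on the series, on what has been measured and on what is new or still open speak of the compounds shown alone.

Working notes on the series in a functional assay on Raji cells (Homo sapiens); on this read-out lower numbers stand for stronger inhibition and higher numbers for weaker inhibition.

Of the compounds shown here, two carry numbers so far. Compound 1 `O=c1[nH]c(=O)n([C@@H]2O[C@H](COP(=O)(O)O)[C@@H](O)[C@H]2O)cc1Br` gives 48 ug/mL in this assay. Compound 2 `O=c1[nH]c(=O)n([C@@H]2O[C@@H]3COP(=O)(O)O[C@H]3[C@H]2O)cc1Cl` gives 278 ug/mL in this assay, the highest of the two numbers shown; its nearest neighbour is compound 1, whose number is lower by a margin beyond the scatter. Among the measured compounds shown here, compound 1 and compound 2 differ from each other in more than one place, so no single step is drawn between them and their two values are taken only as they stand.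

Compound 3 `O=c1[nH]c(=O)n([C@@H]2O[C@@H]3COP(=O)(O)O[C@H]3[C@H]2O)cc1Br` is the next member and awaits measurement in this assay. Against compound 2 the change is bromo in place of chloro on an aromatic carbon. For the measured compounds named here, no measured pair isolates this change, so the expected step from compound 2 to compound 3, a 1.4-fold lower number from compound 2 to compound 3 (0.14 log units; within the scatter), is estimated as small, with no direction beyond the scatter to be relied on. Compound 3 is therefore expected to give about 200 ug/mL in this assay, estimated within 90 ug/mL to 450 ug/mL.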

Compound 3, concentration for 50% inhibition: 210 ug/mL
The estimate for compound 3 lay 1.1-fold (0.02 log units) below the measured number, and the stated range covers the measured number.
By their numbers in this assay, from the lowest: compound 1; then compounds 3 and 2 (each within the scatter of the next).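

In this assay, among the compounds shown here, this is the first measured pair that isolates the group on this aromatic carbon, and on the shared core of compound 2 and compound 3 the step (a 1.3-fold lower number from compound 2 to compound 3 (0.12 log units; within the scatter)) does not tell bromo from chloro. The swap of one single-atom group for the other, with no hydrogen-bond donors or acceptors on either side, therefore gives no readable difference at this position, a finding limited to this one pair. No supporting data bear on this result, so it stands without an explanation.

Still open, from the compounds shown here alone, is whether an amine, a methyl or a carboxylic acid on the same carbon would give a step beyond the scatter. Going by these compounds, it is also open whether chloro and bromo would remain within the scatter of each other on the core of compound 1.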